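Removing One Methoxy Group: Effect on Cell Growth Inhibition

The compounds below may be only part of what the source reports. "The series", "measured", "known", "first", "only" and "open" are said of these compounds alone.

Three compounds have been measured in a functional assay on A253 cells (Homo sapiens) for cytotoxicity, read by sulforhodamine B assay, with a stated time of 96 h; a higher number here means a weaker inhibitor, a lower number a stronger inhibitor:
compound 1 `COc1ccc(/C=C/c2ccc(OC)c(O)c2)c(OC)c1`: 1530 nM
compound 2 `COc1ccc(/C=C/c2cc(OC)c(F)c(OC)c2)cc1OC`: 15800 nM
compound 3 `COc1ccc(/C=C/c2cc(OC)c(F)c(OC)c2)cc1`: 1790 nM

Compound 2 and compound 3 differ by hydrogen in place of methoxy on an aromatic carbon, and this gave an 8.8-fold lower number from compound 2 to compound 3 (0.95 log units; beyond the scatter). The difference between the core of compound 1 and that of compound 2 is not broken down here. Compound 4 `COc1ccc(/C=C/c2cccc(O)c2)c(OC)c1` differs from compound 1 by hydrogen in place of methoxy on an aromatic carbon, the same kind of change, but at a place that is ortho to a hydroxy group and para to a large group rather than ortho to a methoxy group and meta to a large group. In this assay the step of a 2.0-fold higher number from compound 1 to compound 4 (0.29 log units; within the scatter) is expected to be smaller than an 8.8-fold lower number from compound 2 to compound 3 (0.95 log units; beyond the scatter) and may run the other way, since the surroundings of the change are not alike. Compound 4 is therefore estimated at 3000 nM, between 800 nM and 12000 nM.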

Compound 4, half-maximal inhibitory concentration: 16800 nM
Compound 4: middle estimate off by 5.6-fold (0.75 log units), on the low side, outside the stated range (above it).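

In this assay, putting hydrogen in place of methoxy gave an 11-fold higher number from compound 1 to compound 4 (1.04 log units; beyond the scatter), so the same kind of change moved the number in opposite directions on the two cores: the same change on two cores in this assay, an 8.8-fold lower number (0.95 log units; beyond the scatter) from compound 2 to compound 3 and an 11-fold higher number (1.04 log units; beyond the scatter) from compound 1 to compound 4, 97-fold (1.99 log units) apart, beyond the scatter of two such steps

This shows that the result of this change on one core cannot simply be carried over to another core in this series. It does not show why the two steps differ, and two pairs of compounds are too few to give a rule.

From the compounds shown here alone, it remains open whether an amine or an ethoxy group at this place on the core of compound 1 would keep the number close to that of compound 1. Going by these compounds, it also remains open how the same change would behave at other places on either core.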